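The source may report more compounds than this note shows. Statements on the series, on what has been measured and on what is new or still open speak of the compounds shown alone.

Three related compounds have been measured in a functional assay on DU-145 cells (Homo sapiens) for inhibition, read by trypan blue exclusion, with a stated time of 96 h; a higher number here means a weaker inhibitor of growth, a lower number a stronger inhibitor of growth. Compound 1 `O=C(O)c1ccc(C(=O)/C(=C\c2ccc(Br)c([N+](=O)[O-])c2)SCc2ccccc2Cl)cc1` gives 1000 nM, compound 2 `O=C(O)c1ccc(C(=O)/C(=C\c2ccc(O)c([N+](=O)[O-])c2)SCc2ccc(Br)cc2)cc1` gives 50000 nM, and compound 3 `CN(C)c1ccc(/C=C(/SCc2ccc(Br)cc2)C(=O)c2ccc(C(=O)O)cc2)cc1` gives 50000 nM. Compound 3 is therefore level with compound 2, and the two share the highest number of the three, while compound 1 stands lower by a margin well beyond the scatter.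

The next structure, compound 4 `O=C(O)c1ccc(C(=O)/C(=C\c2ccc(Br)c([N+](=O)[O-])c2)SCc2ccc(Br)cc2)cc1`, keeps the rest of compound 3 and exchanges one group on a double-bonded chain carbon bound to a double-bonded chain carbon: 4-bromo-3-nitrophenyl in place of 4-(dimethylamino)phenyl on a double-bonded chain carbon bound to a double-bonded chain carbon. Going by the values given here, the only measured step at this place is no change at the digits printed from compound 2 to compound 3 (within the scatter), where 4-(dimethylamino)phenyl took the place of 4-hydroxy-3-nitrophenyl. That step alone gives no reason to expect movement. However, compound 1 already carries the incoming 4-bromo-3-nitrophenyl group and gives 1000 nM. Among the compounds with values here, it also differs from compound 4 elsewhere in its structure, so no measured step isolates the effect of this group.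

A lower number is therefore expected in this assay, though its size is uncertain, and the estimated change is a 13-fold lower number from compound 3 to compound 4 (1.10 log units; beyond the scatter). The expected value for compound 4 is 4000 nM, with an estimated range from 800 nM to 25000 nM.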

Compound 4, concentration for 50% growth inhibition: 1000 nM
The estimate for compound 4 lay 4.0-fold (0.60 log units) above the measured number, and the stated range covers the measured number.
By their numbers in this assay, from the lowest: compounds 1 and 4 (each within the scatter of the next); then compounds 2 and 3 (each within the scatter of the next).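

In this assay, 4-bromo-3-nitrophenyl in place of 4-(dimethylamino)phenyl on a double-bonded chain carbon bound to a double-bonded chain carbon gives a 50-fold lower number from compound 3 to compound 4 (1.70 log units; beyond the scatter), so the number at this position can move widely, which the earlier exchange there, with no change at the digits printed from compound 2 to compound 3 (within the scatter), gave no sign of. The sharpest comparison is bromo in place of hydroxy on an aromatic carbon, with a 50-fold lower number from compound 2 to compound 4 (1.70 log units; beyond the scatter): the nitro group is present in both compounds, so this single exchange goes with the whole drop, and the lower number does not come from the nitro group alone. At the other end of the molecule, 4-bromophenyl in place of 2-chlorophenyl on a saturated chain carbon bound to a sulfur gives no change at the digits printed from compound 1 to compound 4 (within the scatter), which shows that the lower number holds with either of these two groups at that place.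

The compounds shown leave open whether fluoro or methoxy in place of bromo on that aromatic carbon would keep the lower number, and whether bromo would still do so without the nitro group. Nothing available explains why these exchanges have the effects seen here.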